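Replacing tert-Butyl with Phenethyl on the Five-Membered Ring

The compounds below may be only part of what the source reports. "The series", "measured", "known", "first", "only" and "open" are said of these compounds alone.

Compound 1: `CCCCCc1cn([C@H]2C[C@H](n3cc(C)c(=O)[nH]c3=O)O[C@@H]2CO)nn1`, 311000 nM in an assay on isolated protein for inhibition of thymidine kinase, cytosolic (Homo sapiens), read by scintillation counting; a higher number here means a weaker inhibitor, a lower number a stronger inhibitor
Compound 2: `Cc1cn([C@H]2C[C@H](n3cc(C(C)(C)C)nn3)[C@@H](CO)O2)c(=O)[nH]c1=O`, 114000 nM

Compound 2 stands at the lower of the two numbers, set apart from compound 1 by a 2.7-fold lower number from compound 1 to compound 2 (0.44 log units; beyond the scatter). Compound 3 `Cc1cn([C@H]2C[C@H](n3cc(CCc4ccccc4)nn3)[C@@H](CO)O2)c(=O)[nH]c1=O` carries phenethyl in place of tert-butyl on an aromatic carbon. Among the measured compounds shown here, only that one modest step bears on this change: a pentyl chain gave the higher number, a tert-butyl the lower. Since the phenethyl group is again a chain rather than a compact branched group, a modest climb back toward compound 1 is expected, a 1.9-fold higher number from compound 2 to compound 3 (0.29 log units; within the scatter). Compound 3 is estimated at 220000 nM, ranging from 80000 nM to 600000 nM.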

Compound 3, half-maximal inhibitory concentration: 60000 nM
Beside the measured number, compound 3's estimate is 3.7-fold (0.56 log units) above it, outside the stated range (below it).
By their numbers in this assay, from the lowest: compounds 3 and 2 (each within the scatter of the next); then compound 1.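

In this assay, phenethyl, with its six-membered aromatic ring of carbon only, cannot be told apart from the smaller tert-butyl on this aromatic carbon: a 1.9-fold lower number from compound 2 to compound 3 (0.28 log units; within the scatter). A chain here therefore does not by itself bring the higher number of compound 1, and phenyl in place of propyl along the chain gives a 5.2-fold lower number from compound 1 to compound 3 (0.71 log units; beyond the scatter). No measured evidence accounts for either step. On these data alone, it remains open how an amine or a carboxylic acid on this carbon, or a longer chain ending in phenyl, would read.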